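This account rests on a few compounds, and the source may have more. Where it says the series, first, only, none or still open, it means among the compounds named here.

Working notes on the series in a functional assay on HeLa cells (Homo sapiens) for cytotoxicity, read by MTT assay, with a stated time of 24 h; on this read-out lower numbers stand for stronger inhibition and higher numbers for weaker inhibition. Compound 1 `COc1ccc(/C=C2\SC(=O)N(Cc3ccc(C(=O)O)cc3)C2=O)cc1` gives 40000 nM in this assay. Compound 2 `O=C(O)c1ccc(CN2C(=O)S/C(=C\c3ccccc3)C2=O)cc1` gives 72000 nM, and the step from compound 1 to compound 2, hydrogen in place of methoxy on an aromatic carbon, is a 1.8-fold higher number from compound 1 to compound 2 (0.26 log units; within the scatter). Compound 3 `COc1cc(/C=C2\SC(=O)N(Cc3ccc(C(=O)O)cc3)C2=O)cc(OC)c1OC` gives 30000 nM. Compound 2 therefore shows the highest of the three numbers; its gap to compound 1 lies within the scatter, its gap to compound 3 beyond it.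

Compound 4 `Cn1cccc1/C=C1\SC(=O)N(Cc2ccc(C(=O)O)cc2)C1=O` has not been tested. Its change from compound 2: 1-methyl-1H-pyrrol-2-yl in place of phenyl on a double-bonded chain carbon bound to a double-bonded ring carbon. Going by the values given here, the only measured step that touches the same part of the shared core is the one from compound 1 to compound 2, a 1.8-fold higher number from compound 1 to compound 2 (0.26 log units; within the scatter), which stayed within the scatter. Among the compounds with values here, no measured pair exchanges phenyl for another ring, so the entry of 1-methyl-1H-pyrrol-2-yl rests on no directly comparable step. All three measured numbers sit within a narrow span, and from compound 2 to compound 4 no step beyond the scatter is expected in this assay, a 1.4-fold lower number from compound 2 to compound 4 (0.16 log units; within the scatter). Compound 4 is estimated at 50000 nM, with a range from 20000 nM to 150000 nM.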

Compound 4, half-maximal inhibitory concentration: 90000 nM
Compound 4: middle estimate off by 1.8-fold (0.26 log units), on the low side; low and high end bracket the measured number.
By their numbers in this assay, from the lowest: compounds 3, 1, 2 and 4 (each within the scatter of the next, the first and the last beyond it).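

In this assay, 1-methyl-1H-pyrrol-2-yl in place of phenyl on a double-bonded chain carbon bound to a double-bonded ring carbon gives a 1.3-fold higher number from compound 2 to compound 4 (0.10 log units; within the scatter) and stays within the scatter, so at this position a five-membered aromatic ring with a hetero atom reads the same as the six-membered carbon ring of compound 2. Set against the 4-methoxyphenyl group, the same ring gives a 2.3-fold higher number from compound 1 to compound 4 (0.35 log units; beyond the scatter) and is the first listed single-place step in the series to pass the scatter, though only modestly, while compound 2 stays within the scatter of both compound 1 and compound 4. The data shown offer no explanation for either step.

As far as these compounds go, what an amine or a hydroxyl group on the aromatic ring at this position would do remains open, as does the contribution of the methyl group on the 1-methyl-1H-pyrrol-2-yl ring. From the compounds shown here alone, the carboxylic acid is common to all four compounds, so the effect of an ester or an amide in its place also remains open.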